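This account rests on a few compounds, and the source may have more. Where it says the series, first, only, none or still open, it means among the compounds named here.

Working notes on the series, followed in an ADME assay on microsomes from liver (Rattus norvegicus) for metabolic stability, read by LC-MS, using NADPH, at 37 degrees C; a lower number here means that the compound disappears faster, a higher number that the compound lasts longer. Compound 1 `Cc1cc(C)c(-c2nc(CN3CCC(C(=O)NCCCN4C[C@H](C)C[C@H](C)C4)CC3)c(C)o2)c(C)c1` gives > 0.5 h, which is a limit and not a number. Compound 2 `Cc1ccccc1-c1nc(CN2CCC(C(=O)NCCCN3CCC(C)(C)CC3)CC2)c(C)o1` gives > 0.5 h, also a limit. Among the compounds with values here, compound 1 can therefore be placed only by a bound, and the series so far consists of the limit of > 0.5 h in this assay, at which 2 of the 2 values shown sit.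

Compound 3 `Cc1oc(-c2ccc(Cl)cc2)nc1CN1CCC(C(=O)NCCCN2C[C@H](C)C[C@H](C)C2)CC1` keeps the core of compound 1 and carries 4-chlorophenyl in place of 2,4,6-trimethylphenyl on an aromatic carbon. Within the data shown here, no measured pair shows a change at this place, so the size of the step in this assay cannot be read from the data. The only anchor for the expectation is compound 1 at its limit of > 0.5 h. No change beyond the scatter is expected, and the estimated step is a number no higher from compound 1 to compound 3 (the limit leaves the size open). For compound 3 the estimated half-life is 0.5 h, with an expected range of 0.25 h to 1 h.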

Compound 3, half-life: > 0.5 h
Compound 3 was reported as a limit; the forecaster's own chance of this, stated with the estimate: 60%; the middle value lies on the limit itself.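

No step can be read from compound 1 to compound 3, since both are reported as a limit and not as a number: the limit of > 0.5 h in this assay, at which 3 of the 3 values shown sit.

The compounds shown leave open how long each actually lasts in this assay, and whether 4-chlorophenyl in place of 2,4,6-trimethylphenyl changes the half-life at all.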